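Swapping Methoxy for Fluoro on a Fused Ring Core

A few compounds are considered here, and "the series" means these few. Any claim that something is new, unique, unknown or untested is made for them only; others in the source may bear on it.

Within the data shown here, compound 2 `COc1ccc2c(c1)CC/C2=C\C(N)=O` gives 18% in a functional assay on the whole organism with Rattus norvegicus as the target, at a dose of 20 mg/kg by the oral route (on this read-out lower numbers stand for less inhibition and higher numbers for more inhibition at the one dose given (going by the name of the read-out)), the lower of the two numbers measured so far. Among the measured compounds shown here, its only neighbour is compound 1 `NC(=O)/C=C1\CCc2cc(Cl)ccc21`, which in this assay gives 30%. For the measured compounds named here, the single measured step, a number 12 percentage points lower from compound 1 to compound 2 (beyond the scatter), is the only guide available. Compound 3 `NC(=O)/C=C1\CCc2cc(F)ccc21` differs from compound 2 by fluoro in place of methoxy on an aromatic carbon. Because the earlier step of a number 12 percentage points lower from compound 1 to compound 2 (beyond the scatter) ran against the methoxy group, returning to a halogen is expected to raise inhibition by roughly a number 8 percentage points higher from compound 2 to compound 3 (within the scatter), though fluoro is not chloro and the gain may be smaller. Compound 3 is therefore estimated at 26%, within 12% to 40%.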

Compound 3, a percentage reported as inhibition, in the whole organism at one dose (the size of the read-out at that dose, not a potency): 54%
Compound 3: the middle estimate sits 28 percentage points below what was measured, outside the stated range (above it).
By their numbers in this assay, from the lowest: compound 2; then compound 1; then compound 3.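

In this assay fluoro in place of methoxy gives a number 36 percentage points higher from compound 2 to compound 3 (beyond the scatter) on the shared core. Fluoro in place of chloro gives a number 24 percentage points higher from compound 1 to compound 3 (beyond the scatter) at the same aromatic carbon, so the two halogens are not interchangeable at this position. No available measurement explains this difference.

On these data alone, how an amine or a carboxylic acid at this position would compare remains open. As far as these compounds go, whether the order of these three compounds would hold at other doses is also open.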